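This account rests on a few compounds, and the source may have more. Where it says the series, first, only, none or still open, it means among the compounds named here.

Working notes on the series. Compound 1 `N#CC1=C(N)Oc2c(N)cc3nc4ccccc4nc3c2C12C(=O)N(Cc1cnnn1-c1ccc(Cl)cc1)c1ccccc12`, compound 2 `N#CC1=C(N)Oc2c(N)cc3nc4ccccc4nc3c2C12C(=O)N(Cc1cnnn1-c1ccc([N+](=O)[O-])cc1)c1ccccc12` and compound 3 `N#CC1=C(N)Oc2c(N)cc3nc4ccccc4nc3c2C12C(=O)N(Cc1cnnn1-c1ccc([N+](=O)[O-])cc1[N+](=O)[O-])c1ccccc12` share a core and differ only in the aryl group on the triazole nitrogen. In a functional assay on MCF7 cells (Homo sapiens) for antiproliferative activity, read by MTT assay, with a stated time of 48 h (on this read-out lower numbers stand for stronger inhibition and higher numbers for weaker inhibition), compound 1 gives > 50000 nM, a limit of the assay rather than a number. In this assay compound 2 likewise gives > 50000 nM, again a limit. Going by the values given here, compound 3 is the only one with a number in this assay, giving 20900 nM. Compound 2 and compound 3 differ by nitro in place of hydrogen on an aromatic carbon, and this gives an at least 2.3-fold lower number from compound 2 to compound 3 (0.37 log units; beyond the scatter). Compound 2 and compound 1 differ by chloro in place of nitro on an aromatic carbon, which gives a step that the two limits leave unreadable from compound 2 to compound 1, the two limits the limit of > 50000 nM in this assay, at which 2 of the 3 values shown sit, leaving its size unreadable.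

Compound 4 `N#CC1=C(N)Oc2c(N)cc3nc4ccccc4nc3c2C12C(=O)N(Cc1cnnn1-c1ccc(Cl)cc1[N+](=O)[O-])c1ccccc12` is not yet measured. It differs from compound 3 by chloro in place of nitro on an aromatic carbon, the same kind of change as from compound 2 to compound 1, though here the place is also meta to a nitro group. The earlier step has no readable size, so the expectation rests mainly on compound 3 at 20900 nM: compound 4 is expected to stay near it, with an expected step of a 1.4-fold higher number from compound 3 to compound 4 (0.16 log units; within the scatter). Compound 4 is estimated at 30000 nM in this assay, between 12000 nM and 80000 nM, with a fair chance that only a limit is returned.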

Compound 4, half-maximal inhibitory concentration: > 50000 nM
Compound 4: a limit, no number; the forecaster's own chance of this, stated with the estimate: 40%; middle value at least 1.6-fold (0.22 log units) away from the limit.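

Chloro in place of nitro, at a place meta to a nitro group, gives an at least 2.3-fold higher number from compound 3 to compound 4 (0.37 log units; beyond the scatter) in this assay, so in this one pair the change goes with a weaker read-out. As far as these compounds go, compound 4 gives > 50000 nM, a limit and not a number, so the full size of this step stays unknown. The same change from compound 2 to compound 1 cannot be read, nor can the other new steps, so it cannot be said whether the change has the same size with and without the second nitro group: the limit of > 50000 nM in this assay, at which 3 of the 4 values shown sit.

From the compounds shown here alone, all four compounds carry the shared core and differ only in the aryl group on the triazole nitrogen, so the change on any other core remains open. Also open, going by these compounds, is whether an amine or a carboxylic acid in place of the nitro group of the 2,4-dinitrophenyl would give a number in this assay.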